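Compound 2 to compound 4: methoxy in place of chloro

A few compounds are considered here, and "the series" means these few. Any claim that something is new, unique, unknown or untested is made for them only; others in the source may bear on it.

Among the measured compounds shown here, in a functional assay on MCF7 cells (Homo sapiens) for inhibition, read by sulforhodamine B assay, with a stated time of 48 h (on this read-out lower numbers stand for stronger inhibition of growth and higher numbers for weaker inhibition of growth), compound 2 `O=C1CC(c2ccc(Cl)cc2)Nc2c(Br)cc(Br)cc21` gives 146 nM as the only actual number in the set. Compound 1 `O=C1CC(c2ccc(F)cc2)Nc2c(Br)cc(Br)cc21` reads < 100 nM here, which is a limit of the assay. Compound 3 `O=C1CC(c2ccc([N+](=O)[O-])cc2)Nc2c(Br)cc(Br)cc21` reads < 100 nM here, also a limit. Any ranking is held back by the limit of < 100 nM in this assay, at which 2 of the 3 values shown sit, in these data.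

Compound 4 `COc1ccc(C2CC(=O)c3cc(Br)cc(Br)c3N2)cc1` differs from compound 2 through methoxy in place of chloro on an aromatic carbon with methoxy in place of chloro on an aromatic carbon. For the measured compounds named here, no methoxy compound has been measured yet. Given an at least 1.4-fold higher number from compound 1 to compound 2 (0.16 log units; that floor lies within the scatter) and an at least 1.4-fold lower number from compound 2 to compound 3 (0.16 log units; that floor lies within the scatter) as the only steps with a readable floor, each within the scatter, no step beyond the scatter is expected in this assay for this change. The remaining comparison is a step that the two limits leave unreadable from compound 1 to compound 3 and it offers nothing to read. The estimated change is a 1.5-fold lower number from compound 2 to compound 4 (0.16 log units; within the scatter) and stays within the scatter. For compound 4 the estimate is 100 nM with an expected range from 35 nM to 300 nM for a single measurement.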

Compound 4, concentration for 50% growth inhibition: > 100000 nM
Compound 4: only a limit was reported (the forecaster's own chance of this, stated with the estimate: 45%); at least 1000-fold (3.00 log units) between middle value and limit.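

In this assay, compound 4 reads > 100000 nM, which is a limit of the assay and not a number: the limit of > 100000 nM in this assay, at which 1 of the 4 values shown sits.

On the aromatic carbon para to a large group, the chloro, fluoro and nitro compounds showed no readable step beyond the scatter, whereas methoxy gives an at least 680-fold higher number from compound 2 to compound 4 (2.83 log units; beyond the scatter), an at least 1000-fold higher number from compound 3 to compound 4 (3.00 log units; beyond the scatter) and an at least 1000-fold higher number from compound 1 to compound 4 (3.00 log units; beyond the scatter). This position is therefore not indifferent to the group it carries, and among the four compounds methoxy alone stands apart, although the step between compound 1 and compound 3 cannot be read.

The compounds shown leave open whether a hydroxy, an ethoxy or a dimethylamino group at this carbon would track methoxy or the chloro, fluoro and nitro groups. As far as these compounds go, the full size of each new step also stays open, as each rests on at least one limit.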